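A few compounds are considered here, and "the series" means these few. Any claim that something is new, unique, unknown or untested is made for them only; others in the source may bear on it.

Measured compounds:
- compound 1 `CC(=O)NCc1cccc(Cn2nc(NS(=O)(=O)c3ccc(Cl)s3)c3c(C#N)cccc32)c1` gives 2.5 in a physicochemical assay for lipophilicity; on this read-out higher numbers stand for higher lipophilicity and lower numbers for lower lipophilicity
- compound 2 `CC(=O)NCc1cccc(Cn2nc(NS(=O)(=O)c3ccc(Cl)s3)c3c(CO)cccc32)c1` gives 2.6 in this assay
- compound 3 `COc1cccc2c1c(NS(=O)(=O)c1ccc(Cl)s1)nn2Cc1cccc(CNC(=O)C2COC2)c1` gives 4 in this assay

Compound 3 stands highest of the three in this assay: compound 2 comes nearest, with a gap beyond the scatter, and compound 1 lies furthest, also beyond the scatter. Within the data shown here, the only single-point step measured is a number 0.10 log units higher from compound 1 to compound 2 (within the scatter); it exchanges groups on the aromatic carbon of the shared core and does not touch the amide end of the molecule.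

Compound 4 `CN[C@H](C)C(=O)NCc1cccc(Cn2nc(NS(=O)(=O)c3ccc(Cl)s3)c3c(OC)cccc32)c1` differs from compound 3 as follows: 1-(methylamino)ethyl in place of oxetan-3-yl on a carbonyl carbon. Among the measured compounds shown here, no measured step bears on this exchange, so the expectation rests on the size and direction that such a swap of a ring for an open chain carrying one donor and one acceptor usually brings, which is downward. The step is therefore estimated at a number 1.30 log units lower from compound 3 to compound 4 (beyond the scatter), with wide uncertainty. For compound 4 in this assay the estimated value is 2.7, expected between 1.7 and 3.7.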

Compound 4, distribution coefficient: 3.1
Beside the measured number, compound 4's estimate is 0.40 log units below it; measured number inside the range.
By their numbers in this assay, from the lowest: compounds 1 and 2 (each within the scatter of the next); then compound 4; then compound 3.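

Among these compounds, the earlier step changed only an aromatic carbon of the shared core, so this is the first reading at the carbonyl carbon whose other neighbour is the amide-type nitrogen. In this assay there is a number 0.90 log units lower from compound 3 to compound 4 (beyond the scatter) when 1-(methylamino)ethyl takes the place of oxetan-3-yl. Both groups have 4 heavy atoms, but the entering group has no ring, carries a hydrogen-bond donor and has a defined stereocentre, and nothing measured here says which of these differences matters.

The compounds shown leave open where a plain ethyl chain, or azetidin-3-yl, a four-membered ring holding a nitrogen, would fall in this assay at this carbonyl carbon. Also open, from the compounds shown here alone, is whether the mirror-image form of 1-(methylamino)ethyl would give the same number as compound 4 does.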